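A few compounds are considered here, and "the series" means these few. Any claim that something is new, unique, unknown or untested is made for them only; others in the source may bear on it.

Of the compounds shown here, two built on one shared core have been measured so far in a functional assay on DU-145 cells (Homo sapiens) for cytotoxicity, read by MTT assay, with a stated time of 68 h; on this read-out lower numbers stand for stronger inhibition and higher numbers for weaker inhibition. Compound 1 (`O=C(/C=C/c1cccc(OCc2ccccc2)c1)c1ccc([N+](=O)[O-])cc1`) gives 52500 nM, while compound 2 (`O=C(/C=C/c1cccc(OCc2ccccc2)c1)c1ccc(Br)cc1`) gives 5700 nM, the lower of the two numbers and so the stronger inhibition. Compound 3 (`O=C(/C=C/c1cccc(OCc2ccccc2)c1)c1ccc(Cl)c(Cl)c1Cl`) keeps the core and changes one group: 2,3,4-trichlorophenyl in place of 4-bromophenyl on a carbonyl carbon. In words, this puts 2,3,4-trichlorophenyl in place of 4-bromophenyl on a carbonyl carbon.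

Among the compounds with values here, only one measured step bears on this change. It is a 9.2-fold lower number from compound 1 to compound 2 (0.96 log units; beyond the scatter), made with bromo in place of nitro on an aromatic carbon. That step shows that a swap on this ring can move the number by a modest amount. However, it involves a nitro group, which plays no part in the new change, so it offers no direction for compound 3. The best guess is therefore little movement, with a wide margin on either side. The expected result is a 1.1-fold lower number from compound 2 to compound 3 (0.06 log units; within the scatter). In this assay, compound 3 is estimated at 5000 nM, with an expected range from 1700 nM to 17000 nM.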

Compound 3, half-maximal inhibitory concentration: 6400 nM
Beside the measured number, compound 3's estimate is 1.3-fold (0.11 log units) below it; the range from low to high includes it.
By their numbers in this assay, from the lowest: compounds 2 and 3 (each within the scatter of the next); then compound 1.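

In this assay, the change at this carbonyl carbon gives a 1.1-fold higher number from compound 2 to compound 3 (0.05 log units; within the scatter), so 2,3,4-trichlorophenyl and 4-bromophenyl cannot be told apart here, even though the two groups differ in their halogen atoms and in their heavy-atom counts. The other new comparison, to the nitro-bearing ring, gives an 8.2-fold lower number from compound 1 to compound 3 (0.91 log units; beyond the scatter), which places a second halogen-bearing ring well apart from compound 1 and shows that the earlier gain does not depend on bromine alone. Among these three compounds, the halogen-bearing rings of compound 2 and compound 3 go together, while the 4-nitrophenyl ring of compound 1 stands apart, and no supporting measurement is available to explain this result.

On these data alone, what remains open is whether the match between compound 2 and compound 3 would hold for a simpler ring, such as 4-chlorophenyl, which would help separate the kind of halogen from the number of halogens on the ring. It is also unknown whether an amine or a carboxylic acid on this ring would give a number near that of compound 2 or near that of compound 1.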